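Swapping Sulfur for Tellurium on a Shared Side Chain

The compounds below may be only part of what the source reports. "The series", "measured", "known", "first", "only" and "open" are said of these compounds alone.

Three compounds have been measured:
Compound 1, `COc1ccc(N(CC(=O)NCCCSc2ccccc2)C(=O)CCSC2=C(C)C(=O)c3ccccc3C2=O)cc1`, gives 4.2 in a physicochemical assay for lipophilicity, read by HPLC, measured as octanol-water partition; a higher number here means a more lipophilic compound, a lower number a more polar compound.
Compound 2, `COc1ccc(N(CC(=O)NCCC[Te]c2ccccc2)C(=O)CCSC2=C(C)C(=O)c3ccccc3C2=O)cc1`, gives 1.97 in this assay.
Compound 3, `COc1ccc(N(CC(=O)NCCCSc2ccccc2)C(=O)c2ccccc2)cc1`, gives 3.1 in this assay.

Compound 1 and compound 2 share a core and differ in one place: a group of 7 heavy atoms (6 carbon, 1 tellurium; one six-membered aromatic ring of carbon only) in place of a group of 7 heavy atoms (6 carbon, 1 sulfur; one six-membered aromatic ring of carbon only), on a saturated chain carbon, three bonds along the chain from an amide-type nitrogen. That change brought a number 2.23 log units lower from compound 1 to compound 2 (beyond the scatter). Compound 3 carries a smaller core; the difference between its core and that of compound 1 is not broken down here, and the two values show that compound 3 sits between compound 1 and compound 2 in this assay.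

Compound 4, `COc1ccc(N(CC(=O)NCCC[Te]c2ccccc2)C(=O)c2ccccc2)cc1`, is not yet measured. It stands to compound 3 as compound 2 stands to compound 1, with the same change in the same place: a group of 7 heavy atoms (6 carbon, 1 tellurium; one six-membered aromatic ring of carbon only) in place of a group of 7 heavy atoms (6 carbon, 1 sulfur; one six-membered aromatic ring of carbon only), on a saturated chain carbon, three bonds along the chain from an amide-type nitrogen. Going by the values given here, the step from compound 3 to compound 4 is therefore expected to resemble the step from compound 1 to compound 2, which was a number 2.23 log units lower from compound 1 to compound 2 (beyond the scatter); with only one earlier example of this change, the expectation is uncertain. For compound 4 the expected step is a number 2.20 log units lower from compound 3 to compound 4 (beyond the scatter). In this assay compound 4 is estimated at 0.9, with a likely range from 0.2 to 1.6.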

Compound 4, partition coefficient: 1.72
The estimate for compound 4 lay 0.82 log units below the measured number; the whole stated range lies below it.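

In this assay, swapping the sulfur-bearing group for the tellurium-bearing one on the smaller core gave a number 1.38 log units lower from compound 3 to compound 4 (beyond the scatter) and on the larger core gave a number 2.23 log units lower from compound 1 to compound 2 (beyond the scatter). The number therefore fell on both cores, but the fall was not the same size, so the step seen on one core could not simply be copied onto the other. With only these two pairs, this shows neither a general rule for other cores nor how the core alters the size of the step, and nothing given here accounts for that difference in size.

The compounds shown leave open whether the swap would give a similar step with a longer chain carrying the phenylsulfanyl group, or on a core bearing an amine or a carboxylic acid. They also leave open where a compound with a selenium atom in the place of the sulfur or tellurium would fall in this assay on either core.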